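Compound 3 to compound 4: methoxy for amino

This account rests on a few compounds, and the source may have more. Where it says the series, first, only, none or still open, it means among the compounds named here.

Measured in an ADME assay on HEK293 cells (Homo sapiens) for inhibition, read by MTT assay, with a stated time of 2 days; on this read-out lower numbers stand for stronger inhibition and higher numbers for weaker inhibition:
compound 1 `Nc1cccc(/C=C/c2ccccc2)c1`: 84 ug/mL
compound 2 `Oc1ccc(/C=C/c2cccc(O)c2)cc1`: 1.1 ug/mL
compound 3 `Nc1cccc(/C=C/c2ccc(O)cc2)c1`: 7 ug/mL

Compound 3 is second highest of the three numbers, below compound 1 and above compound 2. The next compound is compound 4 `COc1cccc(/C=C/c2ccc(O)cc2)c1`, with methoxy in place of amino on an aromatic carbon. Going by the values given here, no measured step makes this exact change. The closest is the modest 6.4-fold higher number from compound 2 to compound 3 (0.80 log units; beyond the scatter), which exchanges amino and hydroxy at this place. The large 12-fold lower number from compound 1 to compound 3 (1.08 log units; beyond the scatter) concerns the hydroxy in place of hydrogen and bears only as background, since that hydroxy stays in compound 4. A small step towards a lower number is expected in this assay, possibly not beyond the scatter. The estimated change is a 1.4-fold lower number from compound 3 to compound 4 (0.15 log units; within the scatter). The expected value for compound 4 is 5 ug/mL, with an estimated range of 1.3 ug/mL to 20 ug/mL.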

Compound 4, half-maximal inhibitory concentration: 24 ug/mL
Compound 4: the middle estimate sits 4.8-fold (0.68 log units) below what was measured, and the stated range ends below it.
By their numbers in this assay, from the lowest: compound 2; then compound 3; then compound 4; then compound 1.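

In this assay, methoxy in place of amino on this aromatic carbon gives a 3.4-fold higher number from compound 3 to compound 4 (0.54 log units; beyond the scatter), and methyl in place of hydrogen on the oxygen at this place gives a 22-fold higher number from compound 2 to compound 4 (1.34 log units; beyond the scatter). With the other hydroxy kept, the numbers at this place rise from hydroxy through amino to methoxy, so a free hydroxy gives the lowest number of the three groups. Nothing available explains this order.

Open, as far as these compounds go, is where an ethoxy group or a carboxylic acid would fall at this place. Also open, from the compounds shown here alone, is whether the same order holds without the hydroxy on the other ring.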